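Swapping the Aryl Group: From Compound 3 to Compound 4

The source may hold more compounds than are shown below. What is called first, only, known or untested is meant among the compounds shown, and "the series" means these compounds.

Of the compounds shown here, three built on one shared core have been tested in a functional assay on CHO cells for antagonist activity at Glucagon receptor (Homo sapiens), read by cAMP accumulation, with stated times of 30 min and 45 min; a higher number here means a weaker inhibitor, a lower number a stronger inhibitor. Compound 1 `C[C@H](c1ccc(C(=O)NCCC(=O)O)cc1)N1C(=O)C(c2cccc(OC(F)(F)F)c2)=N[C@]12CC[C@@H](C(C)(C)C)CC2` gives 840 nM. Compound 2 `C[C@H](c1ccc(C(=O)NCCC(=O)O)cc1)N1C(=O)C(c2ccccc2F)=N[C@]12CC[C@@H](C(C)(C)C)CC2` gives 350 nM, and compound 3 `C[C@H](c1ccc(C(=O)NCCC(=O)O)cc1)N1C(=O)C(c2cccc(Cl)c2)=N[C@]12CC[C@@H](C(C)(C)C)CC2` gives 480 nM. Among these three numbers compound 3 is the second highest; its gap to compound 2 is within the scatter, and so is its gap to compound 1, so the three cannot be placed in a reliable order.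

Compound 4 `C[C@H](c1ccc(C(=O)NCCC(=O)O)cc1)N1C(=O)C(c2ccc(F)cc2)=N[C@]12CC[C@@H](C(C)(C)C)CC2` has not yet been measured. It differs from compound 3 in one place: 4-fluorophenyl in place of 3-chlorophenyl on a carbon with a double bond to nitrogen.

The measured steps that bear on this change are the earlier swaps of the same ring. There was a 2.4-fold lower number from compound 1 to compound 2 (0.38 log units; beyond the scatter), a 1.8-fold lower number from compound 1 to compound 3 (0.24 log units; within the scatter) and a 1.4-fold higher number from compound 2 to compound 3 (0.14 log units; within the scatter). Only the first of these lies beyond the scatter, and it is modest; the other two lie within it. Changing the substituent on this ring has so far moved the number only a little. The estimated step is therefore a 1.1-fold lower number from compound 3 to compound 4 (0.06 log units; within the scatter), which means no change beyond the scatter is expected. Compound 4 is estimated at 420 nM, with an expected range from 200 nM to 900 nM.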

Compound 4, half-maximal inhibitory concentration: 430 nM
The estimate for compound 4 lay 1.0-fold (0.01 log units) below the measured number, within the range that was stated.
By their numbers in this assay, from the lowest: compounds 2, 4, 3 and 1 (each within the scatter of the next, the first and the last beyond it).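

Compound 2 and compound 4 carry the same fluorine at different places on the ring, and a 1.2-fold higher number from compound 2 to compound 4 (0.09 log units; within the scatter) shows no readable difference between the 2-fluorophenyl and 4-fluorophenyl groups in this assay for this pair. The swap from 3-chlorophenyl to 4-fluorophenyl alters both the halogen and its place on the ring at once, yet a 1.1-fold lower number from compound 3 to compound 4 (0.05 log units; within the scatter) gives no readable difference either, and this single pair cannot show what each of those two alterations does alone. Within the data shown here, the comparison with 3-(trifluoromethoxy)phenyl gives a 2.0-fold lower number from compound 1 to compound 4 (0.29 log units; within the scatter) and so stays unresolved, while the 2-fluorophenyl group of compound 2 is the only one whose step from compound 1 is printed as beyond the scatter, which means that the two fluorophenyl groups do not behave identically against compound 1 even though they cannot be told apart from each other.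

Every group shown at this position is a phenyl ring bearing one halogen or trifluoromethoxy, so it stays open whether an amine or a carboxylic acid on that ring, or a longer chain in its place, would move the number further. Nothing available explains why these rings read so alike.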